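A Longer Unsaturated Chain on a Macrocyclic Amide Nitrogen

A few compounds are considered here, and "the series" means these few. Any claim that something is new, unique, unknown or untested is made for them only; others in the source may bear on it.

Two macrocyclic peptide-like compounds have been measured in a functional assay on P388 cells (Mus musculus) for cytotoxicity; on this read-out lower numbers stand for stronger inhibition and higher numbers for weaker inhibition. Compound 1 `COc1ccc(C[C@H]2C(=O)N[C@@H](C)C(=O)N(C)[C@H]3Cc4ccc(cc4)Oc4cc(ccc4OC)C[C@@H](C(=O)N[C@H](C)C(=O)N[C@@H](CS)C(=O)N2C)N(C)C3=O)cc1` gives 363 nM in this assay. Compound 2 `CCCCCN1C(=O)[C@@H](C)NC(=O)[C@@H]2Cc3ccc(OC)c(c3)Oc3ccc(cc3)C[C@@H](C(=O)N2C)N(C)C(=O)[C@H](C)NC(=O)[C@H](Cc2ccc(OC)cc2)N(C)C(=O)[C@@H]1C` gives 21.4 nM, the lowest of the two numbers; its gap to compound 1 lies beyond the usual scatter, so compound 2 is the stronger inhibitor of the pair. The two compounds share a core but differ in several places at once, so no single change can be tied to that gap.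

Compound 3 `COc1ccc(C[C@H]2C(=O)N[C@@H](C)C(=O)N(C)[C@H]3Cc4ccc(cc4)Oc4cc(ccc4OC)C[C@@H](C(=O)N[C@H](C)C(=O)N(C/C=C(\C)CCC=C(C)C)[C@@H](C)C(=O)N2C)N(C)C3=O)cc1` has not yet been measured. It is built from compound 2 by one change: 2,6-dimethylhepta-1,5-dien-1-yl in place of butyl on a saturated chain carbon bound to an amide-type nitrogen in a ring. The entering chain is longer than the one it replaces and carries double bonds. Among the measured compounds shown here, the only measured pair differs in more than one place, so there is no measured step that shows how a change of this kind moves the read-out. The step from compound 2 to compound 3 is expected to be small, a 1.5-fold higher number from compound 2 to compound 3 (0.17 log units; within the scatter), within or close to the scatter, with a slight lean toward a higher number. Compound 3 is therefore estimated at 32 nM, with a range from 8 nM to 130 nM.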

Compound 3, half-maximal inhibitory concentration: 49 nM
Estimate against measurement, compound 3: 1.5-fold (0.19 log units) below; the range from low to high includes it.
By their numbers in this assay, from the lowest: compound 2; then compound 3; then compound 1.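

Among the compounds shown here, this is the first single change that can be read at this position. In this assay, putting 2,6-dimethylhepta-1,5-dien-1-yl in place of butyl on a saturated chain carbon bound to an amide-type nitrogen in a ring gives a 2.3-fold higher number from compound 2 to compound 3 (0.36 log units; beyond the scatter), so the larger unsaturated chain weakens inhibition modestly but does not abolish it, and compound 3 still reads 49 nM. Nothing measured explains why the number rises with this change.

Because the entering chain is both longer and unsaturated, this one step cannot show which of those two differences moves the read-out; the saturated 3,7-dimethyloctyl chain on the same nitrogen would separate them. It also remains open how this position responds to a chain that ends in an amine or a carboxylic acid, since every chain shown here is built from carbon alone and has no hydrogen-bond donors or acceptors.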